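Series notes: dihalophenyl ketone variant of compound 3

This account rests on a few compounds, and the source may have more. Where it says the series, first, only, none or still open, it means among the compounds named here.

Compound 3 `COc1ccc(C(=O)/C=C/c2cc(-c3cc(OC)c(OC)c(OC)c3)n[nH]2)cc1` gives the lowest of the three numbers in a functional assay on SNB-19 cells (Homo sapiens) for inhibition, read by sulforhodamine B assay, with a stated time of 48 h (a lower number here means a stronger inhibitor of growth, a higher number a weaker inhibitor of growth), namely 1510 nM. In this assay compound 1 `COc1cc(-c2cc(/C=C/C(=O)c3ccc(N)cc3)[nH]n2)cc(OC)c1OC` gives 2340 nM and compound 2 `COc1cc(-c2cc(/C=C/C(=O)c3ccc(Cl)c(Cl)c3)[nH]n2)cc(OC)c1OC` gives 9830 nM; the nearest to compound 3 is compound 1 (a 1.5-fold lower number from compound 1 to compound 3 (0.19 log units; within the scatter)), the furthest is compound 2 (a 6.5-fold lower number from compound 2 to compound 3 (0.81 log units; beyond the scatter)). Compound 4 `COc1cc(-c2cc(/C=C/C(=O)c3ccc(F)c(F)c3)[nH]n2)cc(OC)c1OC` differs from compound 3 by 3,4-difluorophenyl in place of 4-methoxyphenyl on a carbonyl carbon. Among the measured compounds shown here, two measured steps bear on this: a 4.2-fold higher number from compound 1 to compound 2 (0.62 log units; beyond the scatter) and a 6.5-fold lower number from compound 2 to compound 3 (0.81 log units; beyond the scatter), both of which place a 3,4-dihalophenyl on the carbonyl carbon at a higher number than an aminophenyl or methoxyphenyl. A modest rise beyond the scatter is therefore expected in this assay, a 3.3-fold higher number from compound 3 to compound 4 (0.52 log units; beyond the scatter). Compound 4 is estimated at 5000 nM, with a range from 2000 nM to 12000 nM.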

Compound 4, concentration for 50% growth inhibition: 3640 nM
Compound 4: the middle estimate sits 1.4-fold (0.14 log units) above what was measured; measured number inside the range.
By their numbers in this assay, from the lowest: compounds 3, 1 and 4 (each within the scatter of the next, the first and the last beyond it); then compound 2.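

In this assay, the two 3,4-dihalophenyl groups on the carbonyl carbon are not equivalent: 3,4-difluorophenyl in place of 3,4-dichlorophenyl gives a 2.7-fold lower number from compound 2 to compound 4 (0.43 log units; beyond the scatter). The cost of 3,4-difluorophenyl is resolved only against 4-methoxyphenyl, with a 2.4-fold higher number from compound 3 to compound 4 (0.38 log units; beyond the scatter), while against 4-aminophenyl there is a 1.6-fold higher number from compound 1 to compound 4 (0.19 log units; within the scatter), so no separation from that group can be claimed. Nothing available accounts for these differences.

Still open, on these data alone, is how a plain phenyl, a hydroxyphenyl or a carboxylic acid-bearing phenyl on the carbonyl carbon would compare. As far as these compounds go, whether these steps hold in other cell lines also remains unknown.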